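From compound 3 to compound 4: one group exchanged

This account rests on a few compounds, and the source may have more. Where it says the series, first, only, none or still open, it means among the compounds named here.

Measured in a functional assay on MCF7 cells (Homo sapiens) for antiproliferative activity, read by MTT assay, with stated times of 24 h and 72 h; on this read-out lower numbers stand for stronger inhibition and higher numbers for weaker inhibition:
Compound 1 `COc1cc(N2C(=O)[C@@H](Oc3ccccc3)[C@H]2c2ccc3ccccc3c2)cc(OC)c1OC`: 282000 nM
Compound 2 `COc1ccc([C@@H]2[C@H](Oc3ccccc3)C(=O)N2c2cc(OC)c(OC)c(OC)c2)cc1[N+](=O)[O-]`: 69000 nM
Compound 3 `COc1cc([C@@H]2[C@H](Oc3ccccc3)C(=O)N2c2cc(OC)c(OC)c(OC)c2)ccc1O`: 32000 nM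

Compound 3 has the lowest number of the three, and its steps to both others lie beyond the scatter. Compound 4 `COc1ccc([C@@H]2[C@H](Oc3ccccc3)C(=O)N2c2cc(OC)c(OC)c(OC)c2)c(N)c1O` keeps the shared core but replaces the 4-hydroxy-3-methoxyphenyl group on a saturated ring carbon: a group of 10 heavy atoms (7 carbon, 1 nitrogen, 2 oxygen; one six-membered aromatic ring of carbon only) in place of a group of 9 heavy atoms (7 carbon, 2 oxygen; one six-membered aromatic ring of carbon only), on a saturated ring carbon. Two measured steps change the group at this place: an 8.8-fold lower number from compound 1 to compound 3 (0.95 log units; beyond the scatter) and a 2.2-fold lower number from compound 2 to compound 3 (0.33 log units; beyond the scatter). Both are modest, and neither involves the entering group, so they give no firm direction in this assay. The expected change is small: a 1.3-fold lower number from compound 3 to compound 4 (0.11 log units; within the scatter). For compound 4 the estimated value is 25000 nM, with an expected range from 4000 nM to 120000 nM.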

Compound 4, half-maximal inhibitory concentration: 19000 nM
For compound 4 the middle estimate is 1.3-fold (0.12 log units) above the measured one; low and high end bracket the measured number.
By their numbers in this assay, from the lowest: compounds 4 and 3 (each within the scatter of the next); then compound 2; then compound 1.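

In this assay, the group of 10 heavy atoms in compound 4 cannot be told apart from the 4-hydroxy-3-methoxyphenyl group of compound 3 (a 1.7-fold lower number from compound 3 to compound 4 (0.23 log units; within the scatter)). Among the compounds shown here, it still stands clear of the other two groups (a 3.6-fold lower number from compound 2 to compound 4 (0.56 log units; beyond the scatter)), and the step from naphthalen-2-yl (a 15-fold lower number from compound 1 to compound 4 (1.17 log units; beyond the scatter)) is the first large one at this place. No evidence here explains these steps. What remains open is whether this place needs an aromatic ring at all, since every group shown has one; a carboxylic acid or a longer chain here would test that.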